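Tert-butyl for phenyl on a shared core

This account rests on a few compounds, and the source may have more. Where it says the series, first, only, none or still open, it means among the compounds named here.

Measured so far:
compound 1, `O=C(Nc1ccccc1)O/N=C1\N[C@H](CO)[C@@H](O)[C@H](O)[C@H]1O`: > 100000 nM
compound 2, `O=C(Nc1ccc(Oc2ccccc2)cc1)O/N=C1\N[C@H](CO)[C@@H](O)[C@H](O)[C@H]1O`: > 100000 nM
compound 3, `O=C(Nc1ccc2nsnc2c1)O/N=C1\N[C@H](CO)[C@@H](O)[C@H](O)[C@H]1O`: > 100000 nM

In an assay on isolated protein for inhibition of alpha-galactosidase (Coffea arabica) (on this read-out higher numbers stand for weaker inhibition and lower numbers for stronger inhibition), compound 1 gives > 100000 nM, which is a limit of the assay and not a number. Compound 2 likewise gives only the limit > 100000 nM. Compound 3 gives the limit > 100000 nM as well. Among the compounds with values here, the single step between measured compounds, a step that the two limits leave unreadable from compound 1 to compound 2, therefore carries no readable size, and the limit of > 100000 nM in this assay, at which 3 of the 3 values shown sit, is all that the three values show.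

Compound 4, `CC(C)(C)NC(=O)O/N=C1\N[C@H](CO)[C@@H](O)[C@H](O)[C@H]1O`, differs from compound 1 by tert-butyl in place of phenyl on an amide-type nitrogen. Within the data shown here, no measured step bears on this change, so nothing points to a departure from the limit. Compound 4 is expected at 100000 nM, with a range from 30000 nM to 300000 nM. This estimate means an expected step of a number no higher from compound 1 to compound 4 (the limit leaves the size open).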

Compound 4, half-maximal inhibitory concentration: > 100000 nM
Compound 4 gave a limit, no number; the forecaster's own chance of this, stated with the estimate: 85%; the middle value sits exactly at the limit.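

Within the data shown here, compound 4, like compound 1, gives only a limit and no number in this assay, so no step between them can be read: the limit of > 100000 nM in this assay, at which 4 of the 4 values shown sit. The compounds shown leave open whether any change on the shared core gives a readable number in this assay.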